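Methyl to Hydrogen on the Ring: A Step at the Limit

This account rests on a few compounds, and the source may have more. Where it says the series, first, only, none or still open, it means among the compounds named here.

Compound 1 has the structure `O=C(Nc1cccnc1)c1ccc(Cl)cc1F`. In an ADME assay on cells for inhibition of cytochrome P450 11B1, mitochondrial (Homo sapiens), read by HTRF (a higher number here means a weaker inhibitor, a lower number a stronger inhibitor), compound 1 gives > 3000 nM, which is a limit of the assay rather than a number.
Compound 2 has the structure `Cc1ccc(C(=O)Nc2cccnc2)cc1`. In this assay compound 2 gives > 3000 nM, again a limit and not a number.
Compound 3 has the structure `Cc1cc(Cl)ccc1C(=O)Nc1cccnc1`. In this assay compound 3 gives > 3000 nM, also a limit and not a number.

Compound 3 therefore stands at the limit, where all three measured compounds sit (the limit of > 3000 nM in this assay, at which 3 of the 3 values shown sit); none of them is separated from another, and none can be called stronger or weaker. Among the measured compounds shown here, the only step between measured compounds that differ in one place, a step that the two limits leave unreadable from compound 1 to compound 3, has no readable size because both of its ends are limits (the limit of > 3000 nM in this assay, at which 3 of the 3 values shown sit).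

Compound 4, `O=C(Nc1cccnc1)c1ccc(Cl)cc1`, differs from compound 3 by hydrogen in place of methyl on an aromatic carbon. The measured step from compound 1 to compound 3 concerns a different exchange and gives no size, so nothing measured tells the direction or size of this change in this assay. Compound 4 is expected to give 5000 nM, within 2000 nM to 20000 nM, most probably reported only as a limit. The expected step that the limit leaves unreadable from compound 3 to compound 4 is therefore none beyond the scatter.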

Compound 4, half-maximal inhibitory concentration: > 3000 nM
Compound 4 was reported as a limit (the forecaster's own chance of this, stated with the estimate: 80%); the middle value is on the limit's open side.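

No size can be read for the steps from compound 1, compound 2 or compound 3 to compound 4, because each of these steps has a limit at both ends: the limit of > 3000 nM in this assay, at which 4 of the 4 values shown sit.

The compounds shown leave open how strongly any of them acts in this assay, and whether exchanging methyl, fluoro, chloro or hydrogen changes that at all.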